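The compounds below may be only part of what the source reports. "The series", "measured", "known", "first", "only" and "open" are said of these compounds alone.

Of the compounds shown here, three built on one shared core have been tested in a functional assay on the whole organism with Canis familiaris (Canis lupus familiaris) as the target; on this read-out lower numbers stand for an effect already at smaller amounts and higher numbers for an effect only at larger amounts of compound. Compound 1, `Cc1ccccc1-c1nc2cc[nH]cc-2n1`, gives 2.2 mg/kg in this assay. Compound 2, `Cc1cccc(-c2nc3cc[nH]cc-3n2)c1`, gives 1 mg/kg. Compound 3, `Cc1ccc(-c2nc3cc[nH]cc-3n2)cc1C`, gives 5.2 mg/kg. Compounds 1 and 2 contain the same atoms joined differently; the difference between their two cores is not broken down here, and their two values simply show compound 2 with the lower number. Compound 3 comes from compound 2 by a single change, (methyl in place of hydrogen on an aromatic carbon), and that change made a 5.2-fold higher number from compound 2 to compound 3 (0.72 log units; beyond the scatter), a step toward needing more compound for the same effect.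

Compound 4, `Cc1ccc(-c2nc3cc[nH]cc-3n2)c(C)c1`, has not yet been measured. It comes from compound 1 by methyl in place of hydrogen on an aromatic carbon. The surroundings of the new methyl are not identical to those in the earlier step: from compound 2 to compound 3 the methyl entered ortho to a methyl group, whereas from compound 1 to compound 4 it enters meta to a methyl group, in both cases para to a group of 9 heavy atoms. It is therefore the same kind of change, not the same change. Within the data shown here, compound 4 is expected to show a 3.2-fold higher number from compound 1 to compound 4 (0.50 log units; beyond the scatter), because the one measured example of this kind of change gave a 5.2-fold higher number from compound 2 to compound 3 (0.72 log units; beyond the scatter), with the shift in place adding uncertainty. Compound 4 is estimated at 7 mg/kg, with a likely range from 2.5 mg/kg to 20 mg/kg.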

Compound 4, dose for half-maximal effect: 1.4 mg/kg
Beside the measured number, compound 4's estimate is 5.0-fold (0.70 log units) above it; measured number outside the range, below it.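

In this assay, adding a further methyl group gave a 1.6-fold lower number from compound 1 to compound 4 (0.20 log units; within the scatter), so on this core the added methyl makes no difference that can be told apart from the usual variation between repeated measurements. Set beside the earlier example, this shows that the change does not carry a fixed shift from one core to the other in this series, and that the first result alone was a poor guide to the second: the same change on two cores in this assay, a 5.2-fold higher number (0.72 log units; beyond the scatter) from compound 2 to compound 3 and a 1.6-fold lower number (0.20 log units; within the scatter) from compound 1 to compound 4, 8.2-fold (0.91 log units) apart, beyond the scatter of two such steps. It does not show why the two results part, since the new methyl also sits in different surroundings in the two pairs, here meta to a methyl group, and two pairs cannot separate the effect of the core from that of the position or give a rule for other cores.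

All the compounds shown carry only methyl groups on the six-membered aromatic ring of carbon, so they leave open how a longer chain, an amine or a carboxylic acid would behave in this assay. They also leave open whether the same methyl step would follow either result on a third core.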